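Two inactive nucleoside analogues and a thiophene variant

A few compounds are considered here, and "the series" means these few. Any claim that something is new, unique, unknown or untested is made for them only; others in the source may bear on it.

Measured compounds:
Compound 1 `CCS[C@@H]1[C@H](SCC)[C@@H](Cn2cc(-c3ccc(F)cc3)nn2)O[C@H]1n1cc(C)c(=O)[nH]c1=O`. In a functional assay on LAC cells (Homo sapiens) for cytotoxicity, read by MTT assay, with a stated time of 72 h (a lower number here means that less compound is needed, a higher number that more compound is needed for the effect), compound 1 gives >= 100000 nM, which is a limit of the assay rather than a number.
Compound 2 `CCOC(=O)c1cn(C[C@H]2O[C@@H](n3cc(C)c(=O)[nH]c3=O)[C@H](SCC)[C@@H]2SCC)nn1`. In this assay compound 2 gives >= 100000 nM, again a limit of the assay.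

Among the compounds with values here, compound 2 therefore stands at the limit, as does the one other value shown, (the limit of >= 100000 nM in this assay, at which 2 of the 2 values shown sit). Within the data shown here, the only measured step, a step that the two limits leave unreadable from compound 1 to compound 2, cannot be read because both ends are limits. Compound 3 `CCS[C@@H]1[C@H](SCC)[C@@H](Cn2cc(-c3cccs3)nn2)O[C@H]1n1cc(C)c(=O)[nH]c1=O` differs from compound 2 by thiophen-2-yl in place of ethoxycarbonyl on an aromatic carbon. With no readable step to lean on, compound 3 is expected to stay at the limit as well, the step of a number no higher from compound 2 to compound 3 (the limit leaves the size open) being an estimate only. The estimate for compound 3 is 100000 nM, between 30000 nM and 300000 nM.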

Compound 3, half-maximal effective concentration: >= 100000 nM
Compound 3: a limit, no number (the forecaster's own chance of this, stated with the estimate: 75%); the middle value sits exactly at the limit.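

Within the data shown here, compound 3 also sits at a limit of the assay rather than at a number, so no step among compound 1, compound 2 and compound 3 can be read: the limit of >= 100000 nM in this assay, at which 3 of the 3 values shown sit. The compounds shown leave open whether any of these three groups changes the effect in this assay.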